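The compounds below may be only part of what the source reports. "The series", "measured", "known", "first", "only" and "open" are said of these compounds alone.

Compound 1, `Nc1nc2cc(-c3nn(CC4CCCO4)c4ncnc(N)c34)ccc2o1`: 100 nM
Compound 2, `Nc1nc2cc(-c3nn(C[C@H]4CCCO4)c4ncnc(N)c34)ccc2o1`: 100 nM

Both were measured in a functional assay on T98 cells (Homo sapiens) for antiproliferative activity, with a stated time of 5 days; on this read-out lower numbers stand for an effect already at smaller amounts and higher numbers for an effect only at larger amounts of compound. Compound 2 stands level with compound 1 at the digits printed; the step of no change at the digits printed from compound 1 to compound 2 (within the scatter) lies within the scatter, and the only thing separating the two drawings is the fact that one of compounds 1 and 2 is drawn with a defined configuration and the other without, at the place where they differ. The unmeasured compound 3 is `Nc1nc2cc(-c3nn(CC4CCCC4)c4ncnc(N)c34)ccc2o1`. It differs from compound 2 by cyclopentyl in place of oxolan-2-yl on a saturated chain carbon bound to an aromatic nitrogen. Among the measured compounds shown here, none of the measured steps touches this change: the single known step concerns only how the stereocentre is drawn, and it was flat. The change keeps the count of heavy atoms and the ring size but removes the one hydrogen-bond acceptor, so in this assay no step beyond the scatter is expected, with the direction left open. Compound 3 is therefore expected at 150 nM, within 50 nM to 500 nM. This amounts to an expected step of a 1.5-fold higher number from compound 2 to compound 3 (0.18 log units; within the scatter), which should stay inside the scatter.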

Compound 3, half-maximal effective concentration: 10 nM
Compound 3: the middle estimate sits 15-fold (1.18 log units) above what was measured, and the stated range ends above it.
By their numbers in this assay, from the lowest: compound 3; then compounds 1 and 2 (each within the scatter of the next).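

In this assay, the exchange of oxolan-2-yl for cyclopentyl on a saturated chain carbon bound to an aromatic nitrogen is the only change shown that moves the number beyond the scatter: a 10-fold lower number from compound 2 to compound 3 (1.00 log units; beyond the scatter), and likewise a 10-fold lower number from compound 1 to compound 3 (1.00 log units; beyond the scatter). The position therefore responds to the identity of this group, even though the five-membered non-aromatic ring is kept and only its hetero atom gives way to carbon. Nothing available on this series explains the size of this step.

Still open, as far as these compounds go, is how a piperidin-4-yl group, a morpholine or a plain longer alkyl chain would read at this place. The compounds shown also do not tell whether the carbon-only ring must be five-membered, as a cyclohexyl group would test.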